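Ethoxycarbonyl for 4-fluorophenyl on the sulfur chain

The source may hold more compounds than are shown below. What is called first, only, known or untested is meant among the compounds shown, and "the series" means these compounds.

Among the measured compounds shown here, compound 2 (`COc1cc(-c2nnc(SCc3ccc(F)cc3)n2-c2ccc(N(C)C)cc2)cc(OC)c1OC`) gives 44300 nM in a functional assay on HT-29 cells (Homo sapiens) for inhibition, read by MTT assay, with a stated time of 48 h (on this read-out higher numbers stand for weaker inhibition and lower numbers for stronger inhibition), the only actual number so far. Compound 3 (`CCOC(=O)CSc1nnc(-c2cc(OC)c(OC)c(OC)c2)n1-c1ccc(N(C)C)cc1`) follows from compound 2 by one change, ethoxycarbonyl in place of 4-fluorophenyl on a saturated chain carbon bound to a sulfur. For the measured compounds named here, no measured pair isolates this change, so the expectation rests on a single reference. Going by the values given here, compound 1 (`CCOC(=O)CSc1nnc(-c2cc(OC)c(OC)c(OC)c2)n1-c1ccc(OC)cc1`), the only measured compound carrying ethoxycarbonyl, reads > 60000 nM in this assay, and this reading is a limit of the assay. On the strength of that limit, a small step toward weaker inhibition is expected in this assay, not clearly beyond the scatter. The estimated step is a 1.4-fold higher number from compound 2 to compound 3 (0.13 log units; within the scatter). For compound 3 the expected value is 60000 nM, with an estimated range of 30000 nM to 120000 nM.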

Compound 3, half-maximal inhibitory concentration: 28800 nM
The estimate for compound 3 lay 2.1-fold (0.32 log units) above the measured number; the whole stated range lies above it.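

On a saturated chain carbon bound to a sulfur, exchanging 4-fluorophenyl for ethoxycarbonyl leaves this assay essentially unmoved, with a 1.5-fold lower number from compound 2 to compound 3 (0.19 log units; within the scatter); with dimethylamino held on the other aryl group, this position tolerates loss of the aromatic ring without a reading beyond the scatter. Among the compounds shown here, with ethoxycarbonyl held, dimethylamino in place of methoxy on an aromatic carbon gives the first step printed as beyond the scatter, with an at least 2.0-fold lower number from compound 1 to compound 3 (0.31 log units; beyond the scatter). That step starts from a limit of the assay in compound 1, so its true size is not fixed: the limit of > 60000 nM in this assay, at which 1 of the 3 values shown sits.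

Whether the dimethylamino step carries over to compounds with 4-fluorobenzyl on the sulfur cannot be read from the compounds shown. Also open, on these data alone, is whether a carboxylic acid or a primary amide in place of ethoxycarbonyl, or a longer chain on the sulfur, would shift the reading beyond the scatter.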